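The source may hold more compounds than are shown below. What is called first, only, known or untested is meant among the compounds shown, and "the series" means these compounds.

Of the compounds shown here, two have so far been measured in an in vitro functional assay on HEK285-7 cells for antagonist activity at prostaglandin D2 receptor 2 (Homo sapiens), read by BRET and beta-arrestin recruitment; a lower number here means a stronger inhibitor, a higher number a weaker inhibitor. Compound 1 `COc1ccc(C(c2ccccc2)c2nc(-c3ccc(Cl)cc3)c(CC(=O)O)s2)cc1` gives 76 nM in this assay. Compound 2 `O=C(O)Cc1sc(C(c2ccc(F)cc2)c2ccc(F)cc2)nc1-c1ccccc1` gives 240 nM in this assay, the higher of the two numbers, and the gap between compound 2 and compound 1 lies beyond the scatter of repeated measurements. Among the compounds with values here, the two structures differ in more than one place, so no single step between them can be read from these two values.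

Compound 3 `NS(=O)(=O)c1ccc(-c2nc(C(c3ccc(F)cc3)c3ccc(F)cc3)sc2CC(=O)O)cc1` is the unmeasured member of the set. It differs from compound 2 in one place: sulfamoyl in place of hydrogen on an aromatic carbon. Cut one bond further out, the same change reads phenyl to 4-sulfamoylphenyl.

Within the data shown here, no measured pair in this set shows what such a change does in this assay, so the expectation rests on compound 2 alone. The author expects the step of a 1.2-fold lower number from compound 2 to compound 3 (0.08 log units; within the scatter) to be small, in either direction, and most likely within the scatter. Compound 3 is accordingly estimated at 200 nM in this assay, with a range from 60 nM to 700 nM.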

Compound 3, half-maximal inhibitory concentration: > 100000 nM
Compound 3: no number, only a limit; the forecaster's own chance of this, stated with the estimate: 5%; middle value at least 500-fold (2.69 log units) from the limit.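

Within the data shown here, the step from sulfamoyl in place of hydrogen on an aromatic carbon, para to a large group, is the first one-place change in this set, and it is large: an at least 410-fold higher number from compound 2 to compound 3 (2.61 log units; beyond the scatter). This carbon of the phenyl is therefore not indifferent to what it carries, since this one change, with the rest of compound 2 kept, is enough to leave no number for the new compound. Compound 3 has only a limit in this assay, so the step gives a minimum and not a size: the limit of > 100000 nM in this assay, at which 1 of the 3 values shown sits.

The compounds shown cannot tell whether this result belongs to sulfamoyl as a whole or to one part of it, and a single substituent cannot show whether other groups at this carbon, such as methylsulfonyl, a carboxamide or an amine, would behave the same way. The chlorine on the corresponding ring of compound 1 offers no answer, as compound 1 differs from compound 2 and compound 3 in more than one place.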